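Replacing the amino group of compound 1 by a second methylseleno group

The source may hold more compounds than are shown below. What is called first, only, known or untested is meant among the compounds shown, and "the series" means these compounds.

Compound 1 `C[Se]c1nc(N)c2ccccc2n1` gives 88700 nM in a functional assay on HTB-54 cells (Homo sapiens) for cytotoxicity, read by MTT assay, with a stated time of 72 h (on this read-out lower numbers stand for stronger inhibition of growth and higher numbers for weaker inhibition of growth), the highest of the two numbers recorded. Going by the values given here, compound 2 `Nc1nc([SeH])nc2ccccc12` gives 3630 nM, and the one measured step, a 24-fold lower number from compound 1 to compound 2 (1.39 log units; beyond the scatter), concerns the selenium substituent. Compound 3 `CCCCCSc1nc(O)c2ccccc2n1` returns only the assay limit, > 100000 nM, a boundary rather than a number (the limit of > 100000 nM in this assay, at which 1 of the 3 values shown sits). Compound 4 `C[Se]c1nc([Se]C)c2ccccc2n1` differs from compound 1 by a group of 2 heavy atoms (1 carbon, 1 selenium; no ring) in place of one nitrogen atom, on an aromatic carbon. Among the compounds with values here, no measured step touches this position, so the size and direction of the change in this assay cannot be drawn from the series; any step within the scatter, or a move toward the limit, is possible. Compound 4 is therefore expected near 90000 nM, between 25000 nM and 300000 nM, meaning an expected step of a 1.0-fold higher number from compound 1 to compound 4 (0.01 log units; within the scatter).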

Compound 4, concentration for total growth inhibition: 84200 nM
Compound 4: middle estimate off by 1.1-fold (0.03 log units), on the high side; measured number inside the range.
By their numbers in this assay, from the lowest: compound 2; then compounds 4 and 1 (each within the scatter of the next). At a limit, above all of these: compound 3.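

In this assay, the step on this aromatic carbon is a 1.1-fold lower number from compound 1 to compound 4 (0.02 log units; within the scatter), so in this pair the amino group can give way to a second methylseleno group without a change beyond the scatter. Going by these compounds alone, the only step beyond the scatter remains hydrogen in place of methyl on a selenium. Compound 4 returns a number, and the one limit belongs to compound 3: the limit of > 100000 nM in this assay, at which 1 of the 4 values shown sits.

On these data alone, whether a dimethylamino group or a longer alkylseleno chain on this carbon would behave the same way stays open. Also open, as far as these compounds go, is whether hydrogen in place of methyl on a selenium would give a similar step from compound 4.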